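The source may hold more compounds than are shown below. What is called first, only, known or untested is meant among the compounds shown, and "the series" means these compounds.

Measured so far in a functional assay on the whole organism (strain Wistar) for inhibition, with Rattus norvegicus as the target, read by paw edema, with stated times of 30 min and 3 h, at a dose of 200 mg/kg by the oral route; on this read-out higher numbers stand for more inhibition at the one dose given (going by the name of the read-out) and lower numbers for less inhibition:
compound 1, `O=C(O)c1cccc(-n2c(-c3ccccc3)cc3c2CCCC3)c1`, gives 20%
compound 2, `O=C(O)c1cc(-n2c(-c3ccccc3)cc3c2CCCC3)ccc1O`, gives >= 60%
compound 3, `COc1ccc(-n2c(-c3ccccc3)cc3c2CCCC3)cc1C(=O)O`, gives 40%

The value of compound 2 is a limit of the assay and not a number; it sits at the limit of >= 60% in this assay, at which 1 of the 3 values shown sits. Of the two numbers, compound 3 stands highest, with compound 1 nearest, a number 20 percentage points higher from compound 1 to compound 3 (beyond the scatter).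

The next compound, compound 4, `O=C(O)c1cc(-n2c(-c3ccccc3)cc3c2CCCC3)ccc1S`, differs from compound 3 in one place: sulfanyl in place of methoxy on an aromatic carbon. The entering sulfanyl carries a hydrogen-bond donor where the leaving methoxy carried none, so the most telling measured step is a number at least 20 percentage points lower from compound 2 to compound 3 (beyond the scatter), in which a methyl on the oxygen took the donor away and the read-out fell. The two steps from the parent, a number at least 40 percentage points higher from compound 1 to compound 2 (beyond the scatter) and a number 20 percentage points higher from compound 1 to compound 3 (beyond the scatter), show that either oxygen group at this position raises inhibition above hydrogen, the hydroxy more so. For the measured compounds named here, a sulfanyl is neither of these, and no measured step covers sulfur directly, so the expectation rests on the donor being returned.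

For compound 4 a step of a number 10 percentage points higher from compound 3 to compound 4 (within the scatter) is therefore expected, upward and of modest size. The estimate for compound 4 in this assay is 50%, with the range 30% to 70% expected to hold most repeats.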

Compound 4, a percentage reported as inhibition, in the whole organism at one dose (the size of the read-out at that dose, not a potency): 50%
For compound 4 middle estimate and measured number coincide at the digits printed, within the range that was stated.
By their numbers in this assay, from the lowest: compound 1; then compounds 3 and 4 (each within the scatter of the next). At a limit, above all of these: compound 2.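

In this assay, the sulfanyl group at this position, ortho to a carboxy group, lifts the read-out over hydrogen, a number 30 percentage points higher from compound 1 to compound 4 (beyond the scatter), so a gain over compound 1 is no longer seen with oxygen groups alone. The exchange of methoxy for sulfanyl adds a hydrogen-bond donor, yet the step reads a number 10 percentage points higher from compound 3 to compound 4 (within the scatter), so these compounds do not show that the donor count at this position decides the read-out, and compound 3 and compound 4 cannot be told apart here. Compound 2 holds a limit and not a number, and its step reads a number at least 10 percentage points lower from compound 2 to compound 4 (that floor lies within the scatter), so hydroxy and sulfanyl are not separated either.

Open, going by these compounds, is whether an amine or a carboxylic acid at this position would also keep the read-out over that of compound 1, and whether a methyl on the sulfur would lower it as the methyl on the oxygen did between compound 2 and compound 3. Also open is how far compound 2 really reaches, since its value stays a limit: the limit of >= 60% in this assay, at which 1 of the 4 values shown sits.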